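Swapping the amide aryl group: a fluorophenyl variant

The source may hold more compounds than are shown below. What is called first, only, known or untested is meant among the compounds shown, and "the series" means these compounds.

Measured compounds:
Compound 1, `O=C(CSc1nc(Nc2ccccc2)c2ccccc2n1)Nc1ccccc1F`: 9350 nM
Compound 2, `O=C(CSc1nc(Nc2ccccc2)c2ccccc2n1)Nc1cccc([N+](=O)[O-])c1`: 17900 nM
Compound 3, `CCc1cccc(NC(=O)CSc2nc(Nc3ccccc3)c3ccccc3n2)c1`: 12000 nM

All three share one core and differ only in the aryl group carried by the amide-type nitrogen. In a functional assay on NCI-H1975 cells (Homo sapiens) for inhibition, read by MTT assay, with a stated time of 72 h (a lower number here means a stronger inhibitor, a higher number a weaker inhibitor), compound 1 gives 9350 nM, compound 2 gives 17900 nM and compound 3 gives 12000 nM. The steps between them are small: a 1.9-fold higher number from compound 1 to compound 2 (0.28 log units; within the scatter), a 1.3-fold higher number from compound 1 to compound 3 (0.11 log units; within the scatter) and a 1.5-fold lower number from compound 2 to compound 3 (0.17 log units; within the scatter), each within the scatter. Compound 3 therefore sits among numbers that cannot be told apart from one another; its nearest neighbour is compound 1 and its furthest is compound 2, with neither gap beyond the scatter.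

Compound 4, `O=C(CSc1nc(Nc2ccccc2)c2ccccc2n1)Nc1ccc(F)cc1`, has not yet been measured in this assay. Its change from compound 3 is 4-fluorophenyl in place of 3-ethylphenyl on an amide-type nitrogen. The earlier steps shown here bear on this directly, since each also exchanged the aryl group on the amide-type nitrogen, and none of them moved the number beyond the scatter. A fluorophenyl already appears in compound 1, which sits within the scatter of compound 3.

Compound 4 is therefore expected to give about 11000 nM, within 5000 nM to 25000 nM. The expected step is a 1.1-fold lower number from compound 3 to compound 4 (0.04 log units; within the scatter), which is estimated to remain within the scatter.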

Compound 4, half-maximal inhibitory concentration: 16500 nM
Estimate against measurement, compound 4: 1.5-fold (0.18 log units) below, and the stated range covers the measured number.
By their numbers in this assay, from the lowest: compounds 1, 3, 4 and 2 (each within the scatter of the next).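

Compound 4 brings a second fluorophenyl into the series, so the same group can now be compared in two placements: 4-fluorophenyl in place of 2-fluorophenyl gives a 1.8-fold higher number from compound 1 to compound 4 (0.25 log units; within the scatter), and the placement of fluorine on this ring has no readable effect in this assay. The other two exchanges on the amide-type nitrogen give the same picture, with 4-fluorophenyl in place of 3-ethylphenyl (a 1.4-fold higher number from compound 3 to compound 4 (0.14 log units; within the scatter)) and in place of 3-nitrophenyl (a 1.1-fold lower number from compound 2 to compound 4 (0.04 log units; within the scatter)). All four aryl groups now stand within the scatter of one another at this position, and no measurement given here offers an explanation for that.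

As far as these compounds go, what remains open is whether any group at this position can shift the number beyond the scatter, since all four compounds carry a substituted phenyl ring with the shared core unchanged. An amine, a carboxylic acid or a longer alkyl chain on that ring, or a saturated ring such as cyclohexyl in place of the phenyl, would test how far this flat picture extends.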